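Swapping the pyrimidinyl amine of compound 1 for a fluorophenyl

The source may report more compounds than this note shows. Statements on the series, on what has been measured and on what is new or still open speak of the compounds shown alone.

Compound 1 `O=C(NCCCNc1nc(Nc2cncnc2)ncc1C1CC1)C1CCC1` and compound 2 `Cc1nn(C)c2cc(Nc3ncc(C4CC4)c(NCCCNC(=O)C4CCC4)n3)ccc12` share the same core and were both tested in an assay on isolated protein for inhibition of serine/threonine-protein kinase TBK1 (Homo sapiens); a lower number here means a stronger inhibitor, a higher number a weaker inhibitor. Compound 1 gives 3200 nM, the higher of the two numbers, while compound 2 gives 7 nM. The two compounds differ in more than one place, so only their two values can be set side by side, and the gap between them lies beyond the scatter.

Compound 3 `O=C(NCCCNc1nc(Nc2cccc(F)c2)ncc1C1CC1)C1CCC1` has not yet been measured in this assay. It differs from compound 1 by 3-fluorophenyl in place of pyrimidin-5-yl on a nitrogen on an aromatic ring. Among the compounds with values here, with no single-change step between measured compounds to lean on, the author expects a modest step downward, a 3.2-fold lower number from compound 1 to compound 3 (0.51 log units; beyond the scatter), somewhat beyond the scatter but well short of the gap to compound 2. For compound 3 the estimate in this assay is 1000 nM, with a range from 200 nM to 5000 nM.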

Compound 3, half-maximal inhibitory concentration: 8 nM
Compound 3: middle estimate off by 130-fold (2.10 log units), on the high side; measured number below the stated range.
By their numbers in this assay, from the lowest: compounds 2 and 3 (each within the scatter of the next); then compound 1.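

In this assay, the group on this nitrogen turns out to carry a very large share of the activity: 3-fluorophenyl in place of pyrimidin-5-yl gives a 400-fold lower number from compound 1 to compound 3 (2.60 log units; beyond the scatter) with the rest of the molecule unchanged. The earlier pair could not show this, as compound 1 and compound 2 differ in more than one place and their gap could not be tied to any single one. Nothing available accounts for the size of this step.

Open, as far as these compounds go, is how much of the step belongs to the fluorine and how much to the loss of the two ring nitrogens, a question that a plain phenyl or a pyridin-3-yl on the same nitrogen would address. Also open, from the compounds shown here alone, is whether a chlorine or a methoxy group in place of the fluorine would keep the activity of compound 3.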